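Swapping an amine side chain for a nitrile

This account rests on a few compounds, and the source may have more. Where it says the series, first, only, none or still open, it means among the compounds named here.

Measured in a functional assay on Caco-2 cells (Homo sapiens), read by MTT assay, with a stated time of 48 h; on this read-out higher numbers stand for weaker inhibition and lower numbers for stronger inhibition:
Compound 1 `CCn1c(C(=O)NCCCN(C)C)ccc1C(CC)(CC)c1ccc(OCC(=O)C(C)(C)C)c(C)c1`: 1400 nM
Compound 2 `CCn1c(C(=O)NCCN)ccc1C(CC)(CC)c1ccc(OCC(=O)C(C)(C)C)c(C)c1`: 1900 nM
Compound 3 `CCn1c(C(=O)NCCCN(C)C)ccc1C(CC)(CC)c1ccc(OCC(O)C(C)(C)C)c(C)c1`: 1900 nM

Compound 3, at 1900 nM, is level with compound 2 and within the usual scatter of compound 1, so these three compounds show no real separation. Compound 4 `CCn1c(C(=O)N(C)CCC#N)ccc1C(CC)(CC)c1ccc(OCC(O)C(C)(C)C)c(C)c1` differs from compound 3 by (2-cyanoethyl)(methyl)amino in place of (3-(dimethylamino)propyl)amino on a carbonyl carbon. In words, (2-cyanoethyl)(methyl)amino takes the place of (3-(dimethylamino)propyl)amino on a carbonyl carbon.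

Going by the values given here, only one measured step touches this side chain: a 1.4-fold higher number from compound 1 to compound 2 (0.13 log units; within the scatter), with amino in place of (dimethylamino)methyl. The other step, a 1.4-fold higher number from compound 1 to compound 3 (0.13 log units; within the scatter), changes a different place, with 1-hydroxy-2,2-dimethylpropyl in place of (tert-butyl)carbonyl. Neither step goes beyond the scatter, but neither is a close guide. Among the compounds with values here, the side chain kept an amine in the first step, whereas the entering group carries a nitrile instead, and no measured compound shows that kind of swap.

The expectation therefore stays near compound 3 at 1900 nM, with a slight lean towards weaker inhibition and wide margins. The expected result in this assay is a 1.5-fold higher number from compound 3 to compound 4 (0.17 log units; within the scatter), which is no step beyond the scatter. For compound 4 the estimated value is 2800 nM, with an expected range of 800 nM to 10000 nM.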

Compound 4, half-maximal inhibitory concentration: > 50000 nM
Compound 4: only a limit was reported; the forecaster's own chance of this, stated with the estimate: 15%; at least 17-fold (1.25 log units) between middle value and limit.
By their numbers in this assay, from the lowest: compounds 1, 2 and 3 (each within the scatter of the next). At a limit, above all of these: compound 4.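

In this assay compound 4 gives > 50000 nM, which is a limit of the assay and not a number. The step to it, an at least 26-fold higher number from compound 3 to compound 4 (1.42 log units; beyond the scatter), shows that the group on this carbonyl carbon cannot be changed freely, something the earlier step on the same side chain, a 1.4-fold higher number from compound 1 to compound 2 (0.13 log units; within the scatter), gave no sign of, as both of those compounds keep an amine at the end of the chain. The new change alters several things at once: the dimethylamino end of the chain goes, a nitrile comes in, and a methyl takes the place of the amide hydrogen, so the group's hydrogen-bond donors go from 1 to 0.

The compounds shown leave open which of these alterations accounts for the step, and no mechanism can be read from them. A 2-cyanoethylamino group that keeps the amide hydrogen, or a 3-(dimethylamino)propyl chain on a methylated amide nitrogen, would separate the loss of the amine from the loss of that hydrogen.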